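The source may hold more compounds than are shown below. What is called first, only, known or untested is meant among the compounds shown, and "the series" means these compounds.

In an ADME assay on Vero cells (Chlorocebus sabaeus) for cytotoxicity (on this read-out lower numbers stand for stronger inhibition and higher numbers for weaker inhibition), compound 1 `COc1ccc(Cn2cc(CNC(=O)c3ccc([N+](=O)[O-])o3)nn2)cc1O` gives 174000 nM and compound 2 `COc1ccc(Cn2cc(CNC(=O)c3ccc([N+](=O)[O-])o3)nn2)cc1` gives 274000 nM. Compound 2 therefore stands level with compound 1 within the scatter, and no separation between the two can be read from these numbers. The next analogue, compound 3 `O=C(NCc1cn(Cc2ccc(F)c(Cl)c2)nn1)c1ccc([N+](=O)[O-])o1`, keeps the shared core and changes one group: 3-chloro-4-fluorophenyl in place of 4-methoxyphenyl on a saturated chain carbon bound to an aromatic nitrogen. In words, 3-chloro-4-fluorophenyl stands in place of 4-methoxyphenyl on a saturated chain carbon bound to an aromatic nitrogen.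

Among the compounds with values here, only one measured step bears on this change, and only loosely. Replacing hydroxy with hydrogen on an aromatic carbon gives a 1.6-fold higher number from compound 1 to compound 2 (0.20 log units; within the scatter), which alters the same aromatic ring but involves neither halogen and does not remove the methoxy group. Within the data shown here, the data contain no measured halogen analogue, so the size of this change remains poorly defined. A small lean toward a lower number is assumed, but no step beyond the scatter is expected. The expected step is a 1.6-fold lower number from compound 2 to compound 3 (0.21 log units; within the scatter). For compound 3, the estimated value is 170000 nM, with an expected range from 60000 nM to 400000 nM.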

Compound 3, half-maximal inhibitory concentration: 344000 nM
The estimate for compound 3 lay 2.0-fold (0.31 log units) below the measured number; the measured number falls inside the stated range.
By their numbers in this assay, from the lowest: compounds 1, 2 and 3 (each within the scatter of the next).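

In this assay, placing 3-chloro-4-fluorophenyl in place of 4-methoxyphenyl on a saturated chain carbon bound to an aromatic nitrogen gives a 1.3-fold higher number from compound 2 to compound 3 (0.10 log units; within the scatter), so a ring bearing chlorine and fluorine stands level with the methoxy-bearing ring at this position. The wider exchange, with 3-chloro-4-fluorophenyl in place of 3-hydroxy-4-methoxyphenyl at the same place, gives a 2.0-fold higher number from compound 1 to compound 3 (0.30 log units; within the scatter), so even this change, which removes both the hydroxy and methoxy groups, yields no separation that can be read in this series, and the earlier hydroxy-to-hydrogen comparison is no longer the only sign that the ring substituents leave the number flat. No supporting evidence is available to explain this flat picture.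

From the compounds shown here alone, all three groups at this position are substituted phenyl rings, so it remains open whether a group of a different kind there, such as an amine, a carboxylic acid or a longer chain ending in a morpholine, would stand apart from these compounds. Going by these compounds, it also remains open whether changes elsewhere on the shared core would move the number beyond the scatter.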